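A Halophenyl-to-Furanyl Step in a Paw Edema Series

The source may hold more compounds than are shown below. What is called first, only, known or untested is meant among the compounds shown, and "the series" means these compounds.

Compound 1 `NS(=O)(=O)c1ccc2nc(-n3nc(C(F)(F)F)cc3-c3ccc(Br)cc3)sc2c1`: 45%
Compound 2 `NS(=O)(=O)c1ccc2nc(-n3nc(C(F)(F)F)cc3-c3ccc(Cl)cc3)sc2c1`: 44%

Of the compounds shown here, two have been measured in a functional assay on the whole organism (strain Wistar albino) for inhibition, with Rattus norvegicus as the target, read by paw edema, with stated times of 30 min and 1 h, at a dose of 50 mg/kg by the oral route; a higher number here means more inhibition at the dose given (going by the name of the read-out), a lower number less inhibition. Compound 1 gives 45%, and compound 2 gives 44%. Compound 2 stands alongside compound 1 with no real separation: the step of a number 1 percentage points lower from compound 1 to compound 2 (within the scatter) is within the scatter, so the two compounds are indistinguishable on these numbers.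

The next compound is compound 3 `NS(=O)(=O)c1ccc2nc(-n3nc(C(F)(F)F)cc3-c3ccco3)sc2c1`. It differs from compound 2 by furan-2-yl in place of 4-chlorophenyl on an aromatic carbon. Going by the values given here, the only measured step, from bromo to chloro, bears on this change only loosely, since it exchanges one halogen for another rather than one ring for another, and it was within the scatter. Among the compounds with values here, no measured step therefore predicts a shift for compound 3 in either direction, and the expectation is a step of a number 4 percentage points lower from compound 2 to compound 3 (within the scatter), which is not beyond the scatter. On that basis compound 3 is estimated to give 40%, with a range from 22% to 55% that reflects the missing direct precedent.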

Compound 3, a percentage reported as inhibition, in the whole organism at one dose (the size of the read-out at that dose, not a potency): 27%
The estimate for compound 3 lay 13 percentage points above the measured number, within the range that was stated.
By their numbers in this assay, from the lowest: compound 3; then compounds 2 and 1 (each within the scatter of the next).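

In this assay, furan-2-yl in place of the halophenyl ring gives a number 17 percentage points lower from compound 2 to compound 3 (beyond the scatter) and a number 18 percentage points lower from compound 1 to compound 3 (beyond the scatter) and so is the first change shown that moves the number beyond the scatter. The earlier exchange of bromo for chloro, which kept the phenyl ring in place, gave only a number 1 percentage points lower from compound 1 to compound 2 (within the scatter) and so said nothing about how this position, on an aromatic carbon next to the ring nitrogen, responds when the ring itself is replaced; these compounds show that here the replacement of the ring matters while the choice between the two halogens does not register. No measurement in hand accounts for the lower number of compound 3.

The step changes several things at once, exchanging a six-membered carbon ring with its halogen for a five-membered ring with an oxygen, so the compounds shown cannot say which of these goes with the lower inhibition. Going by these compounds, an unsubstituted phenyl ring, a thiophen-2-yl ring or a 4-methoxyphenyl group at the same position would begin to separate these, and how any of them would read at other doses also stays open.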